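Trifluoromethyl replaces methyl on a pyridyl-bearing core

The source may hold more compounds than are shown below. What is called first, only, known or untested is meant among the compounds shown, and "the series" means these compounds.

Within the data shown here, compound 3 `Cc1ccc(-c2cnc(C(=O)CCCCCCc3ccccc3)o2)nc1` is one of three compounds so far examined in an assay on HEK-293T cells for inhibition of diacylglycerol lipase-alpha (Homo sapiens), read by colorimetric assay; on this read-out higher numbers stand for weaker inhibition and lower numbers for stronger inhibition. In this assay compound 3 gives > 10000 nM, which is a limit of the assay and not a number. Compound 1 `O=C(CCCCCCc1ccccc1)c1ncc(Cl)o1` also gives only a limit, > 10000 nM. Compound 2 `COc1ccc(-c2cnc(C(=O)CCCCCCc3ccccc3)o2)cc1` likewise gives only a limit, > 10000 nM. This is summarised by the limit of > 10000 nM in this assay, at which 3 of the 3 values shown sit. The three steps between them, a step that the two limits leave unreadable from compound 1 to compound 2, a step that the two limits leave unreadable from compound 1 to compound 3 and a step that the two limits leave unreadable from compound 2 to compound 3, therefore give no readable size or direction. Compound 4 `O=C(CCCCCCc1ccccc1)c1ncc(-c2ccc(C(F)(F)F)cn2)o1` differs from compound 3 by trifluoromethyl in place of methyl on an aromatic carbon. Among the measured compounds shown here, no measured step touches this methyl group; the only bearing the measured steps have is that every value sits at the limit, so the step to compound 4 in this assay cannot be sized from them. Compound 4 is therefore expected to give 15000 nM, with an estimated range from 3000 nM to 60000 nM. The step this estimate implies, a step that the limit leaves unreadable from compound 3 to compound 4, is expected to be no more than the scatter, if a number is read at all.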

Compound 4, half-maximal inhibitory concentration: > 10000 nM
Compound 4 ended at the assay's limit; the forecaster's own chance of this, stated with the estimate: 80%; the middle value is on the limit's open side.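

No new step can be read between compound 3 and compound 4, since each gives a limit of the assay and not a number in this assay: the limit of > 10000 nM in this assay, at which 4 of the 4 values shown sit.

The compounds shown leave open whether any change to the shared core would give a readable value in this assay.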